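The source may report more compounds than this note shows. Statements on the series, on what has been measured and on what is new or still open speak of the compounds shown alone.

Compound 1 `CC(C)Cc1ccc(C(C)c2nnc(COc3ccc(-c4ccccc4)cc3)o2)cc1` and compound 2 `CCCCNc1nnc(COc2ccc(-c3ccccc3)cc2)s1` share a core in which a biphenyl ether is linked through a five-membered aromatic ring, and both were tested in a functional assay on the whole organism (strain Wistar) for inhibition, with Rattus norvegicus as the target, read by paw edema, with a stated time of 3 h, at a dose of 10 mg/kg by the oral route; on this read-out lower numbers stand for less inhibition and higher numbers for more inhibition at the one dose given (going by the name of the read-out). In this assay compound 1 gives 77.3%, while compound 2 gives 27.3%, the lowest of the two numbers, with compound 1 standing higher by a step beyond the usual scatter. Compound 3 `Cc1ccccc1Nc1nnc(COc2ccc(-c3ccccc3)cc2)s1` has not yet been measured. It differs from compound 2 in one place: 2-methylphenyl in place of butyl on a nitrogen on an aromatic ring. Going by the values given here, since compound 1 and compound 2 differ in more than one place, no single-change step between measured compounds is available to guide an expectation. The step from compound 2 to compound 3 is nevertheless expected to be an increase of moderate size, a number 17.7 percentage points higher from compound 2 to compound 3 (beyond the scatter). Compound 3 is therefore estimated to give 45% in this assay, within a range from 20% to 70%.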

Compound 3, a percentage reported as inhibition, in the whole organism at one dose (the size of the read-out at that dose, not a potency): 25%
Estimate against measurement, compound 3: 20 percentage points above; the measured number falls inside the stated range.
By their numbers in this assay, from the lowest: compounds 3 and 2 (each within the scatter of the next); then compound 1.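

In this assay, putting 2-methylphenyl in place of butyl on the nitrogen gives a number 2.3 percentage points lower from compound 2 to compound 3 (within the scatter) in the read-out, so this pair does not tell a ring-bearing group from an open chain at this position. The larger heavy-atom count of 2-methylphenyl, and the aromatic ring it brings, thus leave the inhibition at this one dose unchanged within the usual scatter. No measured evidence bears on this result.

As far as these compounds go, whether a plain phenyl, a benzyl group, a chain longer than butyl or a chain ending in a carboxylic acid or an amine would read differently on this nitrogen remains open. Going by these compounds alone, with only two groups compared at this place, the pair sets no trend for the position, and it says nothing about the same change on any other core.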